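This account rests on a few compounds, and the source may have more. Where it says the series, first, only, none or still open, it means among the compounds named here.

Going by the values given here, in a functional assay on LNCaP cells (Homo sapiens) for antiproliferative activity (on this read-out higher numbers stand for weaker inhibition and lower numbers for stronger inhibition), compound 1 (`Cn1ncc(Cl)c1-c1cc(C(=O)N[C@@H]2CN[C@H](CCN3CCC(O)CC3)C[C@H]2c2ccc(Cl)c(Cl)c2)oc1Cl`) gives 1140 nM as the higher of the two numbers so far. Compound 2 (`Cn1ncc(Cl)c1-c1cc(C(=O)N[C@@H]2CN[C@H](CCO)C[C@H]2c2ccc(F)c(F)c2)oc1Cl`) gives 60 nM (lower, by a gap beyond the usual scatter). Compound 3 (`Cn1ncc(Cl)c1-c1cc(C(=O)N[C@@H]2CN[C@H](CC(=O)O)C[C@H]2c2ccc(Cl)c(Cl)c2)oc1Cl`) carries carboxy in place of (4-hydroxypiperidin-1-yl)methyl on a saturated chain carbon bound to a saturated ring carbon. Among the compounds with values here, no measured pair isolates this change, so the expectation is loose: a moderate rise in this assay toward weaker inhibition. The estimated size is a 2.6-fold higher number from compound 1 to compound 3 (0.42 log units; beyond the scatter) and it remains uncertain. For compound 3 the expected value is 3000 nM (900 nM to 10000 nM).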

Compound 3, half-maximal inhibitory concentration: 640 nM
Compound 3: middle estimate off by 4.7-fold (0.67 log units), on the high side; the whole stated range lies above it.
By their numbers in this assay, from the lowest: compound 2; then compounds 3 and 1 (each within the scatter of the next).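

Carboxy in place of (4-hydroxypiperidin-1-yl)methyl on a saturated chain carbon bound to a saturated ring carbon gives, in this assay, a 1.8-fold lower number from compound 1 to compound 3 (0.25 log units; within the scatter). This position therefore accepts the loss of the six-membered ring with no change that this read-out can resolve. No available evidence explains this result.

As far as these compounds go, whether a primary amine or a methyl ester at this place would read the same remains open. Compound 2 differs from compound 3 in more than one place, so the dichlorophenyl and difluorophenyl contributions stay unseparated.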